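A few compounds are considered here, and "the series" means these few. Any claim that something is new, unique, unknown or untested is made for them only; others in the source may bear on it.

Measured in a functional assay on GC3/MTK- cells (Homo sapiens) for inhibition; on this read-out lower numbers stand for stronger inhibition and higher numbers for weaker inhibition:
- compound 1 `C#CCN(Cc1ccc2nc(C)nc(O)c2c1)c1ccccc1`: > 10700 nM
- compound 2 `C#CCN(Cc1ccc2nc(C)nc(O)c2c1)c1cccc(C(C)O)c1`: 49000 nM
- compound 3 `C#CCN(Cc1ccc2nc(C)nc(O)c2c1)c1cccc(Br)c1`: 5300 nM

Compound 1 stands at > 10700 nM, which is a limit of the assay and not a number. The account follows the step to compound 4 `C#CCN(Cc1ccc2nc(C)nc(O)c2c1)c1ccc(S(=O)(=O)N2CCOCC2)cc1`, which has not yet been measured. The structural change is (morpholin-4-yl)sulfonyl in place of hydrogen on an aromatic carbon, para to a large group.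

For the measured compounds named here, three measured steps bear on this change, though none of them introduces that group. With 1-hydroxyethyl in place of hydrogen, the result is a step that the limit leaves unreadable from compound 1 to compound 2. With bromo in place of hydrogen, the result is an at least 2.0-fold lower number from compound 1 to compound 3 (0.30 log units; that floor lies within the scatter). With bromo in place of 1-hydroxyethyl, the result is a 9.2-fold lower number from compound 2 to compound 3 (0.97 log units; beyond the scatter).

So replacing hydrogen on this ring has so far given no readable step beyond the scatter, and the only firm gap lies between compound 2 and compound 3. In this assay, going by the values given here, no large step is therefore expected, and its direction stays open. The estimated step is a step that the limit leaves unreadable from compound 1 to compound 4. For compound 4 the expected value is 14000 nM. The estimated range for compound 4 runs from 4000 nM to 50000 nM.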

Compound 4, half-maximal inhibitory concentration: 5200 nM
Compound 4: the middle estimate sits 2.7-fold (0.43 log units) above what was measured; the measured number falls inside the stated range.
By their numbers in this assay, from the lowest: compounds 4 and 3 (each within the scatter of the next); then compound 2.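

In this assay, (morpholin-4-yl)sulfonyl in place of hydrogen, para to a large group, gives an at least 2.0-fold lower number from compound 1 to compound 4 (0.31 log units; beyond the scatter). For the compounds shown here, this is the first replacement of hydrogen on this ring whose step lies beyond the scatter, as the step to compound 2 could not be read and the floor of the step to compound 3 stayed within the scatter. How much lower the number truly lies remains unknown because compound 1 stands at a limit and not at a number: the limit of > 10700 nM in this assay, at which 1 of the 4 values shown sits.

The compounds shown leave open which part of the entering group goes with the step, the sulfonyl link or the morpholine ring, as no compound separates the two, and a plain sulfonamide or a piperidine in place of the morpholine would be needed to tell them apart. They also leave open whether a smaller group at this same place, such as an amine or a carboxylic acid, would give a step of similar size, and whether bromo at this place would match what it gives in compound 3.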